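A Second Methyl on the Central Ring of Compound 2

This account rests on a few compounds, and the source may have more. Where it says the series, first, only, none or still open, it means among the compounds named here.

Compound 1 `O=C1NC(=O)C(Cc2ccc(Oc3cc(C(F)(F)F)ccn3)cc2)S1` and compound 3 `Cc1cc(C(F)(F)F)cc(Oc2ccc(CC3SC(=O)NC3=O)cc2)n1` differ in one place: methyl in place of hydrogen on an aromatic carbon. In a functional assay for agonist activity at Free fatty acid receptor 1 (Homo sapiens), read by FLIPR, in the presence of a further agent that is not named here (a higher number here means that more compound is needed for the effect, a lower number that less compound is needed), compound 1 gives 237 nM, and compound 3 gives 218 nM; the step is a 1.1-fold lower number from compound 1 to compound 3 (0.04 log units; within the scatter). Compound 2 `Cc1cc(Oc2ncc(C(F)(F)F)cc2Cl)ccc1CC1SC(=O)NC1=O` rests on a different core, and the difference between the core of compound 2 and that of compound 1 is not broken down here. In this assay compound 2 gives 10 nM, the lowest of the three numbers and beyond the scatter from both others. Compound 4 `Cc1cc(Oc2ncc(C(F)(F)F)cc2Cl)cc(C)c1CC1SC(=O)NC1=O` arises from compound 2 by the same kind of change: methyl in place of hydrogen on an aromatic carbon. The surroundings differ, though: in compound 3 the methyl enters a six-membered aromatic ring with one nitrogen, next to the ring nitrogen and meta to a trifluoromethyl group, whereas in compound 4 it enters a ring of carbon only, ortho to the (2,4-dioxo-1,3-thiazolidin-5-yl)methyl group and meta to a methyl group. Because a 1.1-fold lower number from compound 1 to compound 3 (0.04 log units; within the scatter) stayed within the scatter, a modest step of a 1.5-fold higher number from compound 2 to compound 4 (0.18 log units; within the scatter) is expected. Compound 4 is therefore estimated at 15 nM, likely between 5 nM and 45 nM.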

Compound 4, half-maximal effective concentration: 5450 nM
For compound 4 the middle estimate is 360-fold (2.56 log units) below the measured one; measured number outside the range, above it.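

On the core of compound 2 in this assay, a methyl in place of hydrogen on an aromatic carbon gives a 550-fold higher number from compound 2 to compound 4 (2.74 log units; beyond the scatter), so far more compound is needed for the effect once this methyl is present. The result of this change therefore did not carry over from one core to the other, as the two steps side by side make plain: the same change on two cores in this assay, a 1.1-fold lower number (0.04 log units; within the scatter) from compound 1 to compound 3 and a 550-fold higher number (2.74 log units; beyond the scatter) from compound 2 to compound 4, 590-fold (2.77 log units) apart, beyond the scatter of two such steps This does not show why the two steps differ, since the methyl enters a different ring at a different place in each pair, and two pairs cannot separate the effect of the core from that of the position or give a rule for the series.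

On these data alone, it remains open whether the large step belongs to methyl alone or would also appear with another group, such as a fluorine atom or an ethyl group, ortho to the (2,4-dioxo-1,3-thiazolidin-5-yl)methyl group. As far as these compounds go, it also remains open how a methyl at that same place would behave on the core of compound 1.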